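The source may report more compounds than this note shows. Statements on the series, on what has been measured and on what is new or still open speak of the compounds shown alone.

Working notes on the series. Within the data shown here, in an assay on microsomes from intestine for inhibition of acyl-CoA:cholesterol acyltransferase (Oryctolagus cuniculus) (a lower number here means a stronger inhibitor, a higher number a weaker inhibitor), compound 1 `CC(C)c1cccc(C(C)C)c1OC(=O)NC(=O)SCc1ccc(Cl)cc1` gives 160 nM, and compound 2 `CC(C)c1cccc(C(C)C)c1OC(=O)NC(=O)SC1CCCCC1` gives 97 nM; the one step in the set, a 1.6-fold lower number from compound 1 to compound 2 (0.22 log units; within the scatter), lies within the scatter, so compound 1 and compound 2 cannot be separated on these numbers. Compound 3 `CCCCCCCCCCSC(=O)NC(=O)Oc1c(C(C)C)cccc1C(C)C` differs from compound 1 by nonyl in place of 4-chlorophenyl on a saturated chain carbon bound to a sulfur. Among the measured compounds shown here, the only measured step bearing on this sulfur substituent is the one from compound 1 to compound 2, which was within the scatter, so no step beyond the scatter is expected in this assay for compound 3. The estimate for compound 3 is 150 nM, with a range of 50 nM to 450 nM, which means an expected step of a 1.1-fold lower number from compound 1 to compound 3 (0.03 log units; within the scatter).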

Compound 3, half-maximal inhibitory concentration: 130 nM
The estimate for compound 3 lay 1.2-fold (0.06 log units) above the measured number; low and high end bracket the measured number.
By their numbers in this assay, from the lowest: compounds 2, 3 and 1 (each within the scatter of the next).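

In this assay, nonyl in place of 4-chlorophenyl on a saturated chain carbon bound to a sulfur gives a 1.2-fold lower number from compound 1 to compound 3 (0.09 log units; within the scatter). The earlier step to compound 2 kept a ring on the sulfur, whereas compound 3 shows that a chain with no ring and no chlorine also stays within the scatter of compound 1. Nothing available bears on why the number holds across this change.

Open, going by these compounds, is whether a methyl group, a much longer chain, or a chain ending in an amine or a carboxylic acid would move the number beyond the scatter.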